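This account rests on a few compounds, and the source may have more. Where it says the series, first, only, none or still open, it means among the compounds named here.

Measured compounds in a functional assay on HBL-100 cells (Homo sapiens) for inhibition, read by sulforhodamine B assay, with a stated time of 48 h; a lower number here means a stronger inhibitor of growth, a higher number a weaker inhibitor of growth:
compound 1 `COC(=O)[C@@]1(C)CCC=C2[C@@H]1CC[C@@H](C)[C@]2(C)Cc1c[nH]c2c(C)cccc12` gives 8000 nM
compound 2 `COC(=O)[C@@]1(C)CCC=C2[C@@H]1CC[C@@H](C)[C@]2(C)Cc1c[nH]c2c(Br)cccc12` gives 18000 nM
compound 3 `COC(=O)[C@@]1(C)CC[C@@H]2C3=C1CC[C@@H](C)[C@]3(C)C[C@@H]1c3cc(C)ccc3N[C@H]21` gives 15000 nM

Compound 1 and compound 2 share one core and differ in a single place, (bromo in place of methyl on an aromatic carbon). In this assay this change gave a 2.3-fold higher number from compound 1 to compound 2 (0.35 log units; beyond the scatter). Compound 3 is built on a different core, made of the same atoms joined differently; the difference between the two cores is not broken down here. In this assay compound 3 stands within the scatter of both compound 1 and compound 2, so no order among the three is read from these values.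

Compound 4 `COC(=O)[C@@]1(C)CC[C@@H]2C3=C1CC[C@@H](C)[C@]3(C)C[C@@H]1c3cc(Br)ccc3N[C@H]21` has not yet been measured. It differs from compound 3 by bromo in place of methyl on an aromatic carbon. For the measured compounds named here, this is the same kind of change as the one from compound 1 to compound 2, not the same: in compound 1 the methyl sits on a ring that is part of a fused or bridged system of two rings, ortho to a fused ring and meta to a fused ring, whereas in compound 3 it sits on a ring that is part of a fused or bridged system of five rings, meta to a fused ring and para to a fused ring.

The expectation for compound 4 rests on one precedent only, the step of a 2.3-fold higher number from compound 1 to compound 2 (0.35 log units; beyond the scatter), measured on the other core. With a single example and the surroundings of the changed carbon not identical, a step of roughly the same size is expected, a 2.0-fold higher number from compound 3 to compound 4 (0.30 log units; within the scatter), with wide bounds. Compound 4 is therefore estimated at 30000 nM in this assay, between 14000 nM and 70000 nM.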

Compound 4, concentration for 50% growth inhibition: 34000 nM
The estimate for compound 4 lay 1.1-fold (0.05 log units) below the measured number; low and high end bracket the measured number.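

In this assay, bromo in place of methyl on an aromatic carbon gave a 2.3-fold higher number from compound 3 to compound 4 (0.36 log units; beyond the scatter), and the size of this step matches that of the earlier one: the same change on two cores in this assay, a 2.3-fold higher number (0.35 log units; beyond the scatter) from compound 1 to compound 2 and a 2.3-fold higher number (0.36 log units; beyond the scatter) from compound 3 to compound 4, 1.0-fold (0.00 log units) apart, within the scatter of two such steps On these two pairs, the change therefore carries from one core to the other with both its direction and its size kept, although the changed carbon on the core of compound 3 belongs to a fused system of five rings, meta to a fused ring and para to a fused ring. This rests on two pairs, a single swap of groups and one assay, so it does not show that the step would hold on a third core or at another aromatic carbon, and it gives no reason for the match.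

The compounds shown leave open whether hydrogen, chloro or methoxy on this aromatic carbon would fall in line with methyl and bromo, or whether any of them would give a stronger inhibitor of growth. They also leave open what happens when the methyl ester, common to all four compounds, gives way to a carboxylic acid or an amide.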